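The source may hold more compounds than are shown below. What is called first, only, known or untested is meant among the compounds shown, and "the series" means these compounds.

Compound 3 `CCc1cc([C@@H]2[C@@H](C(=O)N=C(N)N)C2(C)C)ccc1F` gives the lowest number of the three in a functional assay on AP1 cells with sodium/hydrogen exchanger 1 (Homo sapiens) as the target (a higher number here means a weaker inhibitor, a lower number a stronger inhibitor), at 5 nM; compound 2 `COc1cccc([C@@H]2[C@@H](C(=O)N=C(N)N)C2(C)C)c1` gives 12 nM, and compound 1 `Cc1cc([C@@H]2[C@@H](C(=O)N=C(N)N)C2(C)C)ccc1F` gives 32 nM. Compound 4 `CC1(C)[C@H](C(=O)N=C(N)N)[C@H]1c1ccc(F)c(Br)c1` differs from compound 3 by bromo in place of ethyl on an aromatic carbon. Among the compounds with values here, the only measured step at this position is a 6.4-fold lower number from compound 1 to compound 3 (0.81 log units; beyond the scatter), which shows that altering the group there can move this assay beyond the scatter. Within the data shown here, no measured compound carries bromo at that position, so the direction of the step is uncertain and the estimate is kept broad. A modest rise in the number is expected, a step of a 2.4-fold higher number from compound 3 to compound 4 (0.38 log units; beyond the scatter). Compound 4 is therefore estimated at 12 nM, within a range from 4 nM to 40 nM.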

Compound 4, half-maximal inhibitory concentration: 3 nM
Estimate against measurement, compound 4: 4.0-fold (0.60 log units) above, and the stated range ends above it.
By their numbers in this assay, from the lowest: compounds 4 and 3 (each within the scatter of the next); then compound 2; then compound 1.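

In this assay, bromo and ethyl on this aromatic carbon cannot be told apart, with a 1.7-fold lower number from compound 3 to compound 4 (0.22 log units; within the scatter), even though bromo has one heavy atom and ethyl two. Methyl, by contrast, is clearly separated from bromo, with an 11-fold lower number from compound 1 to compound 4 (1.03 log units; beyond the scatter), so methyl now stands apart from both of the other groups at this position. Nothing shown gives a reason for these steps.

From the compounds shown here alone, whether chloro, a longer chain such as propyl, or an amine at this position would match bromo and ethyl remains open. Also open, going by these compounds, is whether the same order of groups would hold with the fluoro group replaced.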